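Compound 4: chloro in place of methyl, growth inhibition expected

The compounds below may be only part of what the source reports. "The series", "measured", "known", "first", "only" and "open" are said of these compounds alone.

Measured so far:
Compound 1, `O=[N+]([O-])c1ccc(Cn2cc(COc3ccccc3)nn2)cc1`, in an ADME assay on PANC-1 cells (Homo sapiens) for inhibition, read by MTT assay, with a stated time of 48 h (a lower number here means a stronger inhibitor of growth, a higher number a weaker inhibitor of growth), gives > 100 ug/mL, a limit of the assay.
Compound 2, `Cc1ccc(OCc2cn(Cc3ccc([N+](=O)[O-])cc3)nn2)cc1`, in this assay gives > 100 ug/mL, again a limit.
Compound 3, `Cc1ccc(OCc2cn(Cc3ccc(Cl)cc3)nn2)cc1`, in this assay gives > 100 ug/mL, again a limit.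

Compound 2 thus stands only at a limit in this assay, as do its two neighbours: the limit of > 100 ug/mL in this assay, at which 3 of the 3 values shown sit. Compound 4, `O=[N+]([O-])c1ccc(Cn2cc(COc3ccc(Cl)cc3)nn2)cc1`, differs from compound 2 by chloro in place of methyl on an aromatic carbon. The measured steps on the shared core, a step that the two limits leave unreadable from compound 1 to compound 2 and a step that the two limits leave unreadable from compound 2 to compound 3, read no size, so they give neither direction nor magnitude for the present change. The step expected in this assay is a step that the limit leaves unreadable from compound 2 to compound 4, nothing beyond the scatter. Compound 4 is estimated at 150 ug/mL, within 60 ug/mL to 400 ug/mL, and is expected most likely to be reported as a limit again.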

Compound 4, concentration for 50% growth inhibition: > 100 ug/mL
Compound 4 ended at the assay's limit (the forecaster's own chance of this, stated with the estimate: 80%); the middle value is on the limit's open side.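

Compound 4 gives > 100 ug/mL in this assay, again a limit, so no new step can be read against compound 1 or compound 2. The compounds shown leave open what any change on the shared core does to growth inhibition: the limit of > 100 ug/mL in this assay, at which 4 of the 4 values shown sit.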